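Removing the para alkoxy group from the aniline series

A few compounds are considered here, and "the series" means these few. Any claim that something is new, unique, unknown or untested is made for them only; others in the source may bear on it.

Measured so far:
- Compound 1, `CCOc1ccc(-c2nn3cc(-c4cccc(N)c4)nc3s2)cc1`, a functional assay on HeLa cells (Homo sapiens) for inhibition, read by cell counting, with a stated time of 4 days (a lower number here means a stronger inhibitor, a higher number a weaker inhibitor), 94000 nM
- Compound 2, `C=C(Br)C(=O)Nc1cccc(-c2cn3nc(-c4ccccc4)sc3n2)c1`, this assay 1400 nM
- Compound 3, `COc1ccc(-c2nn3cc(-c4cccc(N)c4)nc3s2)cc1`, this assay >= 250000 nM

Compound 3 sits at the limit of this assay, so its value is a bound and not a number; the limit of >= 250000 nM in this assay, at which 1 of the 3 values shown sits, describes this. Of the three measured compounds, compound 3 is therefore the one with only a range known, and it gives the weakest figure on the numbers shown.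

The change to compound 4, `Nc1cccc(-c2cn3nc(-c4ccccc4)sc3n2)c1`, is hydrogen in place of methoxy on an aromatic carbon. Going by the values given here, only one measured step bears on this part of the molecule: an at least 2.6-fold higher number from compound 1 to compound 3 (0.42 log units; beyond the scatter), a change from ethoxy to methoxy that already moved the number upward and past the limit. Compound 2 carries the same unsubstituted phenyl as compound 4 but differs elsewhere, so its value is not a guide to this step.

With compound 3 at the limit, the direction of the further change cannot be fixed from the data. The number for compound 4 is expected to stay in the weak range, with the step of an at least 1.6-fold lower number from compound 3 to compound 4 (0.22 log units; that floor lies within the scatter) expected to be no larger than the scatter. Compound 4 is estimated at 150000 nM, with a range from 40000 nM to 500000 nM.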

Compound 4, half-maximal inhibitory concentration: 26000 nM
Compound 4: middle estimate off by 5.8-fold (0.76 log units), on the high side; measured number below the stated range.
By their numbers in this assay, from the lowest: compound 2; then compound 4; then compound 1. At a limit, above all of these: compound 3.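

Hydrogen para to a large group does not continue the upward move seen on going from ethoxy to methoxy: an at least 9.6-fold lower number from compound 3 to compound 4 (0.98 log units; beyond the scatter), and a 3.6-fold lower number from compound 1 to compound 4 (0.56 log units; beyond the scatter), so the unsubstituted phenyl gives a lower number than either alkoxy compound. Compound 3 stays a limit and not a number: the limit of >= 250000 nM in this assay, at which 1 of the 4 values shown sits. With this phenyl in place, the group on the aniline nitrogen also counts, as a 19-fold higher number from compound 2 to compound 4 (1.27 log units; beyond the scatter) when hydrogen replaces (1-bromoethenyl)carbonyl.

The compounds shown leave open whether a fluorine, an amine or a longer chain such as propoxy on this carbon would give a number nearer to compound 4 or to compound 1. They also leave open how (1-bromoethenyl)carbonyl on the nitrogen behaves when ethoxy or methoxy is present on the phenyl ring.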